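A few compounds are considered here, and "the series" means these few. Any claim that something is new, unique, unknown or untested is made for them only; others in the source may bear on it.

Measured so far in a functional assay for agonist activity at G protein-coupled receptor 88 (Homo sapiens), read by HTRF and cAMP accumulation; a lower number here means that less compound is needed, a higher number that more compound is needed for the effect:
compound 1 `CC[C@H](C)[C@H](N)CN(C(=O)[C@@H]1C[C@H]1c1ccc(F)cc1)c1ccc(-c2ccccc2)cc1` gives 600 nM
compound 2 `CC(C)C[C@H](N)CN(C(=O)[C@@H]1C[C@H]1c1ccccc1)c1ccc(-c2cccc(C#N)c2)cc1` gives 4500 nM
compound 3 `CC[C@H](C)[C@H](N)CN(C(=O)[C@@H]1C[C@H]1c1ccccc1)c1ccc(-c2ccc(C(F)(F)F)cc2)cc1` gives 340 nM

Compound 3 has the lowest of the three numbers. Its gap to compound 1 lies within the scatter, so no order between those two can be read; compound 2 stands beyond the scatter above both. Compound 4 `CCOC(=O)c1ccc(-c2ccc(N(C[C@@H](N)[C@@H](C)CC)C(=O)[C@@H]3C[C@H]3c3ccccc3)cc2)cc1` follows from compound 3 by one change: ethoxycarbonyl in place of trifluoromethyl on an aromatic carbon. The entering group brings hydrogen-bond acceptors where trifluoromethyl had none. For the measured compounds named here, no measured pair isolates this change, and compound 2, the only compound weaker than compound 3 beyond the scatter, differs from it in two places at once. A small step towards a higher number, if any, is expected, a 1.8-fold higher number from compound 3 to compound 4 (0.25 log units; within the scatter). Compound 4 is estimated at 600 nM, between 200 nM and 2000 nM.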

Compound 4, half-maximal effective concentration: 260 nM
For compound 4 the middle estimate is 2.3-fold (0.36 log units) above the measured one; the measured number falls inside the stated range.
By their numbers in this assay, from the lowest: compounds 4, 3 and 1 (each within the scatter of the next, the first and the last beyond it); then compound 2.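

In this assay, for the compounds shown here, ethoxycarbonyl in place of trifluoromethyl, para to a large group, gives a 1.3-fold lower number from compound 3 to compound 4 (0.12 log units; within the scatter) and so provides the first single-change pair. At this position, a group with 2 hydrogen-bond acceptors replaces one with 0, and no order between the two can be read. Nothing measured bears on this result.

Still open, as far as these compounds go, is whether a carboxylic acid or a primary amide in the same place would also stay within the scatter of compound 4. A longer ester chain is equally untested here.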